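The compounds below may be only part of what the source reports. "The series", "measured", "known", "first", "only" and "open" are said of these compounds alone.

Among the compounds with values here, compound 1, with the structure `NCc1ccc(C(=O)Nc2ccncc2F)cc1-c1cccc(C(=O)Nc2ccc(CC(=O)O)cc2)c1`, is one of two compounds measured in an ADME assay on a cell-free system (plasma, Homo sapiens) for metabolic stability, read by LC-MS; on this read-out higher numbers stand for a longer-lived compound and lower numbers for a shorter-lived compound. In this assay compound 1 gives > 2 h, which is a limit of the assay rather than a measured number. A second compound, compound 2 with the structure `CCCOC(=O)c1cccc(C(=O)Nc2cccc(-c3cc(C(=O)Nc4ccncc4F)ccc3CN)c2)c1`, is also on record: in this assay compound 2 gives < 0.0834 h, again a limit and not a number. Neither value is an exact figure, so compound 1 stands at one end of what the assay can report, the end where (the limit of > 2 h in this assay, at which 1 of the 2 values shown sits), while compound 2 sits at the other end, where (the limit of < 0.0834 h in this assay, at which 1 of the 2 values shown sits). The two compounds differ in several places at once. Within the data shown here, no single step between them can be read off.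

Compound 3, with the structure `NCc1ccc(C(=O)Nc2ccncc2F)cc1-c1cccc(C(=O)Nc2cccc(C(=O)O)c2F)c1`, differs from compound 1 in one place only: 3-carboxy-2-fluorophenyl in place of 4-(carboxymethyl)phenyl on an amide-type nitrogen. The acid group is kept in both. A step within the usual scatter is expected, a step that the limit leaves unreadable from compound 1 to compound 3. Compound 3 is therefore estimated to give 3 h in this assay, most likely between 1.5 h and 8 h.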

Compound 3, half-life: > 2 h
Compound 3 ended at the assay's limit; the forecaster's own chance of this, stated with the estimate: 80%; the middle value lies beyond the limit too.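

In this assay compound 3 gives > 2 h, which is a limit and not a number. Compound 1 also sits at a limit, so no step can be read between compound 1 and compound 3. The compounds shown leave open how long either one actually lasts, and whether swapping 4-(carboxymethyl)phenyl for 3-carboxy-2-fluorophenyl makes any difference.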